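Three Hydroxyphenyl-Bearing Cores and One Remaining Measurement

The source may hold more compounds than are shown below. What is called first, only, known or untested is meant among the compounds shown, and "the series" means these compounds.

Compound 1 `Oc1ccc(-c2cc(-c3cccc(O)c3)nc(-c3cccc(O)c3)c2)cc1` and compound 2 `Oc1cccc(-c2cc(-c3cccc(O)c3)nc(-c3cccc(O)c3)c2)c1` share a core and differ in one place: 3-hydroxyphenyl in place of 4-hydroxyphenyl on an aromatic carbon. In an ADME assay on HEK293 cells (Homo sapiens) for cytotoxicity, read by CCK-8 assay, with a stated time of 4 days (on this read-out higher numbers stand for weaker inhibition and lower numbers for stronger inhibition), compound 1 gives 730 nM, and compound 2 gives 740 nM; the step of a 1.0-fold higher number from compound 1 to compound 2 (0.01 log units; within the scatter) is within the scatter. Compound 3 `Oc1ccc(-c2cc(-c3ccccc3O)cc(-c3ccccc3O)n2)cc1` has a different core; how the two cores differ is not broken down here. Compound 3 gives 6990 nM, the weakest inhibition of the three. Compound 4 `Oc1cccc(-c2cc(-c3ccccc3O)cc(-c3ccccc3O)n2)c1` is not yet measured and differs from compound 3 by 3-hydroxyphenyl in place of 4-hydroxyphenyl on an aromatic carbon, the same kind of change as between compound 1 and compound 2, though here the place is next to the ring nitrogen and meta to two 2-hydroxyphenyl groups. Because a 1.0-fold higher number from compound 1 to compound 2 (0.01 log units; within the scatter) stayed within the scatter, the step from compound 3 to compound 4 is expected to be small, a 1.0-fold higher number from compound 3 to compound 4 (0.00 log units; within the scatter). Compound 4 is estimated at 7000 nM, between 3000 nM and 16000 nM.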

Compound 4, half-maximal inhibitory concentration: 730 nM
Estimate against measurement, compound 4: 9.6-fold (0.98 log units) above; measured number below the stated range.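

In this assay, 3-hydroxyphenyl in place of 4-hydroxyphenyl gives a 9.6-fold lower number from compound 3 to compound 4 (0.98 log units; beyond the scatter), which on this read-out means stronger inhibition. The same change therefore does not carry over unchanged between these cores: the same change on two cores in this assay, a 1.0-fold higher number (0.01 log units; within the scatter) from compound 1 to compound 2 and a 9.6-fold lower number (0.98 log units; beyond the scatter) from compound 3 to compound 4, 9.7-fold (0.99 log units) apart, beyond the scatter of two such steps. This shows that the result on one core did not predict the result on the other, but it does not show why they differ, and two cores cannot show how the change would behave on a further core.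

All the compounds shown carry hydroxyphenyl groups, so it remains open whether a methoxy group or an amine in place of the hydroxyl would show the same dependence on the core. As far as these compounds go, it also remains open whether the gap between the cores would hold in other cells.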